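This account rests on a few compounds, and the source may have more. Where it says the series, first, only, none or still open, it means among the compounds named here.

Compound 3 `Cc1cc(Nc2cc(N3CCN(C)CC3)nc(Nc3ccc(S(N)(=O)=O)cc3)n2)n[nH]1` gives 2760 nM in a functional assay on A-431 cells (Homo sapiens) for antiproliferative activity, read by CCK-8 assay, with a stated time of 72 h (on this read-out higher numbers stand for weaker inhibition and lower numbers for stronger inhibition), the highest of the three numbers measured. Compound 1 `Cc1cc(Nc2cc(N3CCN(C)CC3)nc(Nc3ccc(Cl)cc3)n2)n[nH]1` gives 162 nM and compound 2 `Cc1cc(Nc2cc(N3CCN(C)CC3)nc(Nc3ccc(C#N)cc3)n2)n[nH]1` gives 140 nM. Two large steps separate them from it: a 17-fold higher number from compound 1 to compound 3 (1.23 log units; beyond the scatter) and a 20-fold higher number from compound 2 to compound 3 (1.29 log units; beyond the scatter), whereas a 1.2-fold lower number from compound 1 to compound 2 (0.06 log units; within the scatter). Compound 4 `COc1cccc(Nc2nc(Nc3cc(C)[nH]n3)cc(N3CCN(C)CC3)n2)c1` differs from compound 3 by 3-methoxyphenyl in place of 4-sulfamoylphenyl on a nitrogen on an aromatic ring. Among the measured compounds shown here, both large steps bear on this change, since the sulfamoyl that set compound 3 apart is removed; no measured compound carries a 3-methoxyphenyl, so its own contribution is unknown. Compound 4 is therefore expected to fall back toward the region of the other two, with an 11-fold lower number from compound 3 to compound 4 (1.04 log units; beyond the scatter). The estimate for compound 4 is 250 nM, with a range from 80 nM to 800 nM.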

Compound 4, half-maximal inhibitory concentration: 332 nM
Compound 4: the middle estimate sits 1.3-fold (0.12 log units) below what was measured, and the stated range covers the measured number.
By their numbers in this assay, from the lowest: compounds 2 and 1 (each within the scatter of the next); then compound 4; then compound 3.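

On the nitrogen on an aromatic ring, 3-methoxyphenyl shows that a change away from 4-sulfamoylphenyl need not use a chloro or cyano group to give much of the gain in this assay, with an 8.3-fold lower number from compound 3 to compound 4 (0.92 log units; beyond the scatter). It does not reach the other two, however, with a 2.4-fold higher number from compound 2 to compound 4 (0.38 log units; beyond the scatter) and a 2.0-fold higher number from compound 1 to compound 4 (0.31 log units; beyond the scatter). Nothing measured here explains these differences. The compounds shown leave open whether the methoxy group or its place on the phenyl ring sets this result, and how an amine or a carboxylic acid on that ring would read.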